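Carbonyl Substituent Change Weighed Against Three Measured Analogues

The compounds below may be only part of what the source reports. "The series", "measured", "known", "first", "only" and "open" are said of these compounds alone.

Three compounds sharing one core were measured in a functional assay on ACHN cells (Homo sapiens) for inhibition, read by sulforhodamine B assay, with a stated time of 48 h, tested at 0.01 uM; a higher number here means a weaker effect of the compound at the concentration tested, a lower number a stronger effect. Compound 1 `COc1cc(Cl)cc(-c2nn(-c3cccc(NC(=O)Nc4ccc(Cl)c(C(F)(F)F)c4)c3)cc2-c2ccncc2)c1` gives 91%, compound 2 `COc1cc(Cl)cc(-c2nn(-c3cccc(NC(=O)Nc4ccc(Cl)c(Cl)c4)c3)cc2-c2ccncc2)c1` gives 102%, and compound 3 `COc1cc(Cl)cc(-c2nn(-c3cccc(NC(=O)Nc4cccc(C(F)(F)F)c4)c3)cc2-c2ccncc2)c1` gives 108%. The steps are a number 11 percentage points higher from compound 1 to compound 2 (beyond the scatter) and a number 17 percentage points higher from compound 1 to compound 3 (beyond the scatter), whereas a number 6 percentage points higher from compound 2 to compound 3 (within the scatter). Compound 3 therefore sits apart from compound 1 but not from compound 2. Compound 4 `COc1cc(Cl)cc(-c2nn(-c3cccc(NC(=O)c4cccc(C(F)(F)F)c4)c3)cc2-c2ccncc2)c1` differs from compound 3 by 3-(trifluoromethyl)phenyl in place of (3-(trifluoromethyl)phenyl)amino on a carbonyl carbon. None of the three measured steps touches the carbonyl carbon or its amide-type nitrogen; all concern chloro and trifluoromethyl groups on aromatic carbons, and all were modest or within the scatter. The step from compound 3 to compound 4 in this assay is thus expected to be a number 5 percentage points lower from compound 3 to compound 4 (within the scatter), with no direction favoured. Compound 4 is expected to give 103%, between 88% and 118%.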

Compound 4, a percentage reported as activity, at one concentration (the size of the read-out at that concentration, not a potency): 98%
The estimate for compound 4 lay 5 percentage points above the measured number, and the stated range covers the measured number.
By their numbers in this assay, from the lowest: compounds 1, 4, 2 and 3 (each within the scatter of the next, the first and the last beyond it).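

In this assay the first change shown at the carbonyl carbon, which removes the amino link and its hydrogen-bond donor, gives a number 10 percentage points lower from compound 3 to compound 4 (within the scatter) and a number 4 percentage points lower from compound 2 to compound 4 (within the scatter) and a number 7 percentage points higher from compound 1 to compound 4 (within the scatter) with each step within the scatter. Compound 4 is thus not set apart from any of the three earlier compounds, even though compound 1 and compound 3 are set apart from each other. No available evidence explains this result.

Going by these compounds, whether a methylene group or a longer chain on the carbonyl carbon would give a different read-out remains open. So does the effect of an amine on the aromatic ring that this change introduces.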